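The compounds below may be only part of what the source reports. "The series", "measured", "known", "first", "only" and "open" are said of these compounds alone.

For the measured compounds named here, in a functional assay on J774 cells (Mus musculus) for cytotoxicity, read by resazurin assay (on this read-out higher numbers stand for weaker inhibition and lower numbers for stronger inhibition), three compounds built on a shared core have numbers so far. Compound 1 (`OCCCCCC(O)c1ccc(-c2ccc(F)cc2F)cc1`) gives 8000 nM, and compound 2 (`OCCCCCC(O)c1ccc(-c2ccc(Cl)cc2Cl)cc1`) gives 8000 nM. Compound 3 (`O=C(CCCCCO)c1ccc(-c2ccc(F)cc2F)cc1`) gives 6000 nM, a value within the scatter of those of both compound 1 and compound 2. Compound 3 therefore stands level with the other two on these numbers, and the three cannot be ranked in this assay.

Compound 4 (`Cc1cc(C(=O)CCCCCO)ccc1-c1ccc(F)cc1F`) has not yet been measured. It differs from compound 3 in one place: methyl in place of hydrogen on an aromatic carbon. In short, it carries methyl in place of hydrogen on an aromatic carbon. Going by the values given here, no pair of measured compounds differs by a single change, so the data hold no direct precedent for this step. Among the compounds with values here, the only guide is that all three measured values lie within the scatter of one another, and compound 3 at 6000 nM serves as the starting point. On that basis, no change beyond the scatter is expected, and the estimated step is a 1.2-fold lower number from compound 3 to compound 4 (0.08 log units; within the scatter). For compound 4 the estimated value is 5000 nM, with an expected range from 2500 nM to 10000 nM.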

Compound 4, half-maximal inhibitory concentration: 8000 nM
The estimate for compound 4 lay 1.6-fold (0.20 log units) below the measured number, within the range that was stated.
By their numbers in this assay, from the lowest: compounds 3, 1, 2 and 4 (each within the scatter of the next).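

Compound 4 gives the first direct comparison across a single change in this set: in this assay, methyl in place of hydrogen on an aromatic carbon gives a 1.3-fold higher number from compound 3 to compound 4 (0.12 log units; within the scatter). For the compounds shown here, this aromatic carbon, ortho to a group of 8 heavy atoms and meta to a group of 8 heavy atoms, therefore carries one added carbon without a shift beyond the scatter, something the earlier compounds, all with hydrogen there, could not show. That reading rests on a single pair and extends to no other position or shared-core compound, and no measurement bearing on the reason for this outcome is available.

The compounds shown leave open whether any group at this position can move the number beyond the scatter, since a single methyl is the only replacement for hydrogen here, and an amine, a carboxylic acid or a longer chain in its place might behave differently. They also leave open whether methyl at this aromatic carbon would give a similar step in compounds with the core of compound 1 or compound 2, which carry a hydroxyl group in place of the carbonyl.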